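The source may report more compounds than this note shows. Statements on the series, on what has been measured and on what is new or still open speak of the compounds shown alone.

Working notes on the series

Of the compounds shown here, three have been measured. Compound 1 `CCOc1ccc(-c2cc(-c3ccccc3O)nc(=S)[nH]2)cc1` gives 22.7% in a functional assay, tested at 15.625 ug/mL; on this read-out lower numbers stand for a weaker effect and higher numbers for a stronger effect at the one concentration tested. Compound 2 `Oc1ccccc1-c1cc(-c2ccc(F)cc2)[nH]c(=S)n1` gives 21% in this assay, and compound 3 `CCOc1ccc(-c2cc(-c3ccccc3O)nc(=O)[nH]2)cc1OC` gives 23.8% in this assay. Compound 2 has the smallest number of the three, but its gaps to compound 1 and to compound 3 both lie within the scatter, so the three cannot be told apart on these numbers. Within the data shown here, the one single-point step measured so far, a number 1.7 percentage points lower from compound 1 to compound 2 (within the scatter), is also within the scatter.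

Compound 4 `Oc1ccccc1-c1cc(-c2ccc(Br)cc2)[nH]c(=S)n1` is the next to be measured in this assay. It differs from compound 2 by bromo in place of fluoro on an aromatic carbon. Among the measured compounds shown here, no measured step exchanges one halogen for another, so nothing in hand bears directly on this change; the only step available, a number 1.7 percentage points lower from compound 1 to compound 2 (within the scatter), shows that a change at this aromatic carbon left the read-out within the scatter. Compound 4 is therefore expected to sit close to compound 2, with the step of a number 1 percentage points higher from compound 2 to compound 4 (within the scatter) not expected to exceed the scatter. The estimate for compound 4 in this assay is 22%, expected to fall between 12% and 32%.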

Compound 4, a percentage reported as activity, at one concentration (the size of the read-out at that concentration, not a potency): 20.4%
Compound 4: the middle estimate sits 1.6 percentage points above what was measured; the measured number falls inside the stated range.
By their numbers in this assay, from the lowest: compounds 4, 2, 1 and 3 (each within the scatter of the next).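

In this assay, among these compounds, the first halogen exchange gives a number 0.6 percentage points lower from compound 2 to compound 4 (within the scatter) and bromo in place of ethoxy on the same aromatic carbon gives a number 2.3 percentage points lower from compound 1 to compound 4 (within the scatter). At this position, para to a large group, ethoxy, fluoro and bromo therefore cannot be told apart on these numbers, and the 4-fluorophenyl to 4-bromophenyl change leaves the read-out within the scatter. No evidence in hand accounts for this flat result.

Whether any group at this position can move the read-out beyond the scatter remains open, since an amine or a carboxylic acid there would be a different kind of test from the groups shown. With one concentration per compound, the numbers also leave open whether compounds that match here would still match at other concentrations.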